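Ester variation in the side chain of a quinone series

The source may report more compounds than this note shows. Statements on the series, on what has been measured and on what is new or still open speak of the compounds shown alone.

Measured compounds in a functional assay on HeLa cells (Homo sapiens) for cytotoxicity, read by MTT assay; on this read-out higher numbers stand for weaker inhibition and lower numbers for stronger inhibition:
compound 1, `CC(C)=CC[C@@H](OC(=O)CCO)C1=CC(=O)c2c(O)ccc(O)c2C1=O`, 67600 nM
compound 2, `CC(=O)OCCC(=O)O[C@H](CC=C(C)C)C1=CC(=O)c2c(O)ccc(O)c2C1=O`, 17300 nM
compound 3, `CCCC(CC(=O)O[C@H](CC=C(C)C)C1=CC(=O)c2c(O)ccc(O)c2C1=O)OC(C)=O`, 51200 nM

Compound 2 stands lowest of the three numbers in this assay; compound 3 is nearest and compound 1 furthest, both steps beyond the scatter. The change from compound 2 to compound 4, `CC(C)=CC[C@@H](OC(=O)C1CCCOC1)C1=CC(=O)c2c(O)ccc(O)c2C1=O`, is oxan-3-yl in place of 2-acetoxyethyl on a carbonyl carbon.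

Among the measured compounds shown here, two measured steps bear on it. Adding the acetyl to the oxygen on a saturated carbon gave a 3.9-fold lower number from compound 1 to compound 2 (0.59 log units; beyond the scatter), so the acetoxy group that compound 4 loses went with the lowest number. Adding a propyl at the chain carbon gave a 3.0-fold higher number from compound 2 to compound 3 (0.47 log units; beyond the scatter), so more bulk in the side chain raised the number. Compound 4 removes the acetyl ester and adds a ring of about the same size, so a modest upward step from compound 2 is expected, in the direction of compound 1.

Compound 4 is thus estimated at 40000 nM, range 15000 nM to 110000 nM, an expected step of a 2.3-fold higher number from compound 2 to compound 4 (0.36 log units; beyond the scatter).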

Compound 4, half-maximal inhibitory concentration: 60500 nM
Beside the measured number, compound 4's estimate is 1.5-fold (0.18 log units) below it; the measured number falls inside the stated range.
By their numbers in this assay, from the lowest: compound 2; then compounds 3, 4 and 1 (each within the scatter of the next).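

In this assay the oxan-3-yl group does not hold the low number of compound 2: the change gives a 3.5-fold higher number from compound 2 to compound 4 (0.54 log units; beyond the scatter) even though both groups count 6 heavy atoms. The other two steps, a 1.2-fold higher number from compound 3 to compound 4 (0.07 log units; within the scatter) and a 1.1-fold lower number from compound 1 to compound 4 (0.05 log units; within the scatter), both lie within the scatter, so of the four side chains only the 2-acetoxyethyl of compound 2 stands apart, and the 2-hydroxyethyl, 2-acetoxypentyl and oxan-3-yl groups cannot be separated. Nothing available explains the step from compound 2 to compound 4.

On these data alone, whether the lower number of compound 2 needs the acetyl itself or only a capped oxygen on that chain remains open. A 2-methoxyethyl or a propanoyl in place of the acetyl would test this, and an amine at the chain end is also untested here.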